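The compounds below may be only part of what the source reports. "The series", "measured", "known", "first", "only" and "open" are said of these compounds alone.

The series shares one core carrying an aryl amide, and the two measured compounds differ only in the group on the carbonyl carbon: compound 1 `COc1ccc(C(=O)Nc2cccc(-c3oc4cc(-c5ccc(F)cc5)ccc4c(=O)c3O)c2)cc1` and compound 2 `COc1cc(OC)cc(C(=O)Nc2cccc(-c3oc4cc(-c5ccc(F)cc5)ccc4c(=O)c3O)c2)c1`. In a functional assay on HeLa cells (Homo sapiens) for antiproliferative activity, read by CCK-8 assay, with a stated time of 72 h (a lower number here means a stronger inhibitor, a higher number a weaker inhibitor), compound 1 gives 4820 nM, and in this assay compound 2 gives 2700 nM. Going by the values given here, the only step measured so far, a 1.8-fold lower number from compound 1 to compound 2 (0.25 log units; within the scatter), lies within the scatter, so on the numbers compound 2 and compound 1 sit together rather than apart. Compound 3 `O=C(Nc1cccc(-c2oc3cc(-c4ccc(F)cc4)ccc3c(=O)c2O)c1)c1ccc(Cl)nc1` is the next member. The change is 6-chloropyridin-3-yl in place of 3,5-dimethoxyphenyl on a carbonyl carbon. Among the compounds with values here, the one step that bears on it is a 1.8-fold lower number from compound 1 to compound 2 (0.25 log units; within the scatter), a swap of the same kind at the same place, which moved the number little. The expected step of a 1.1-fold higher number from compound 2 to compound 3 (0.05 log units; within the scatter) is therefore set at no more than the scatter, with no clear direction, and a wide range is kept because the entering group is of a new kind. For compound 3 the estimate in this assay is 3000 nM, with a range from 900 nM to 10000 nM.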

Compound 3, half-maximal inhibitory concentration: 4080 nM
For compound 3 the middle estimate is 1.4-fold (0.13 log units) below the measured one; measured number inside the range.
By their numbers in this assay, from the lowest: compounds 2, 3 and 1 (each within the scatter of the next).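

Putting 6-chloropyridin-3-yl on the carbonyl carbon gives a 1.5-fold higher number from compound 2 to compound 3 (0.18 log units; within the scatter) and a 1.2-fold lower number from compound 1 to compound 3 (0.07 log units; within the scatter) in this assay. Going by these compounds alone, this is the first change at this position away from a carbon-only aromatic ring bearing methoxy groups, and it brings in a ring hetero atom and a chlorine, yet all three compounds remain within the scatter of one another. Among these three compounds, then, methoxy groups are not needed to keep the number at this level, and no information here explains that outcome.

It remains open whether any group on this carbonyl carbon can move the number beyond the scatter, as all three groups shown are six-membered aromatic rings. A carboxylic acid, an aliphatic amine or a longer alkyl chain in this place would put that question to a different kind of group.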